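Swapping a benzyloxy for hydroxymethyl in a urea series

This account rests on a few compounds, and the source may have more. Where it says the series, first, only, none or still open, it means among the compounds named here.

Three ureas share one core. Compound 1 `CC(C)c1cccc(C(C)C)c1NC(=O)NCC1(c2ccc(F)cc2)CCCC1` gives 23 nM in an assay on microsomes for inhibition of acyl-CoA:cholesterol acyltransferase (Oryctolagus cuniculus); a higher number here means a weaker inhibitor, a lower number a stronger inhibitor. Compound 2 `CC(C)c1cccc(C(C)C)c1NC(=O)NCC1(c2ccc(Cl)cc2)CCCC1` gives 32 nM, a change of a 1.4-fold higher number from compound 1 to compound 2 (0.14 log units; within the scatter). Compound 3 `CC(C)c1cccc(C(C)C)c1NC(=O)NCC1(c2cccc(OCc3ccccc3)c2)CCCC1` gives 30 nM; this number sits second highest of the three, with compound 2 nearest and compound 1 furthest, both within the scatter.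

Compound 4 `CC(C)c1cccc(C(C)C)c1NC(=O)NCC1(c2cccc(CO)c2)CCCC1` is the next step: hydroxymethyl in place of benzyloxy on an aromatic carbon. Going by the values given here, the only measured step, the halogen swap from compound 1 to compound 2, stayed within the scatter and does not resemble this change, so no close precedent exists.

With so little guidance, compound 4 is expected to give a modestly weaker number, 90 nM, in a range from 25 nM to 350 nM, an expected step of a 3.0-fold higher number from compound 3 to compound 4 (0.48 log units; beyond the scatter).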

Compound 4, half-maximal inhibitory concentration: 15 nM
Compound 4: the middle estimate sits 6.0-fold (0.78 log units) above what was measured; measured number below the stated range.
By their numbers in this assay, from the lowest: compounds 4, 1, 3 and 2 (each within the scatter of the next, the first and the last beyond it).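

Replacing benzyloxy with hydroxymethyl removes an entire aromatic ring at this place, yet in this assay the step is a 2.0-fold lower number from compound 3 to compound 4 (0.30 log units; within the scatter), so this position does not need that ring to keep inhibition at this level. With 3-(hydroxymethyl)phenyl in place of 4-fluorophenyl the step is a 1.5-fold lower number from compound 1 to compound 4 (0.19 log units; within the scatter), and in place of 4-chlorophenyl it is a 2.1-fold lower number from compound 2 to compound 4 (0.33 log units; beyond the scatter), a modest gain. No measurement shown here explains this tolerance. Still open, from the compounds shown here alone, is whether the oxygen of hydroxymethyl matters, which a plain methyl, an aminomethyl or a carboxylic acid on the same aromatic carbon would test.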